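Two Analogues at the Assay Ceiling, and a Third Awaiting Measurement

A few compounds are considered here, and "the series" means these few. Any claim that something is new, unique, unknown or untested is made for them only; others in the source may bear on it.

compound 1, `Cc1ccccc1-n1nncc1CN1C(=O)C2(C(C#N)=C(N)Oc3c2c2nc4ccccc4nc2c2ccccc32)c2ccccc21`: > 50000 nM
compound 2, `N#CC1=C(N)Oc2c(N)cc3nc4ccccc4nc3c2C12C(=O)N(Cc1cnnn1-c1ccc(F)cc1)c1ccccc12`: > 50000 nM

In an ADME assay on L02 cells (Homo sapiens) for antiproliferative activity, read by MTT assay, with a stated time of 48 h (on this read-out lower numbers stand for stronger inhibition and higher numbers for weaker inhibition), compound 1 gives > 50000 nM, which is a limit of the assay and not a number. In this assay compound 2 gives > 50000 nM, again a limit rather than a number. Compound 2 thus stands at the ceiling of what has been measured, and it shares that position with compound 1, since both values rest at the limit of > 50000 nM in this assay, at which 2 of the 2 values shown sit. No step between measured compounds is available, so nothing in the shown data tells how a change of substituent moves the read-out.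

Compound 3, `COc1ccccc1-n1nncc1CN1C(=O)C2(C(C#N)=C(N)Oc3c(N)cc4nc5ccccc5nc4c32)c2ccccc21`, has not yet been measured in this assay. It differs from compound 2 in one place: 2-methoxyphenyl in place of 4-fluorophenyl on an aromatic nitrogen, in words 2-methoxyphenyl in place of 4-fluorophenyl on an aromatic nitrogen. With both shown values sitting at a limit, the step from compound 2 onward is expected to be none beyond the scatter, and the expected step in this assay is a number no higher from compound 2 to compound 3 (the limit leaves the size open). Compound 3 is therefore estimated at 50000 nM in this assay, with a range from 20000 nM to 120000 nM, and it is expected most likely to be reported again only as a limit.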

Compound 3, half-maximal inhibitory concentration: > 50000 nM
Compound 3: no number, only a limit; the forecaster's own chance of this, stated with the estimate: 85%; the middle value lies on the limit itself.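

In this assay compound 3 gives > 50000 nM, which is a limit of the assay and not a number. No step from compound 2 to compound 3 can be read, since both values are limits: the limit of > 50000 nM in this assay, at which 3 of the 3 values shown sit.

The compounds shown leave open whether 2-methoxyphenyl in place of 4-fluorophenyl moves the read-out at all.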